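From Compound 3 to Compound 4: Changing One Aromatic Group

The source may report more compounds than this note shows. Statements on the series, on what has been measured and on what is new or still open speak of the compounds shown alone.

- compound 1 `COc1ccc(/C=C(\C(=O)c2ccc(Br)cc2)S(=O)(=O)c2ccc(Br)cc2)cc1` gives 25000 nM
- compound 2 `COc1cccc(OC)c1/C=C(\C(=O)c1ccc(Br)cc1)S(=O)(=O)c1ccc(Br)cc1` gives 10000 nM
- compound 3 `O=C(/C(=C\c1ccc(Br)c([N+](=O)[O-])c1)S(=O)(=O)c1ccc(Br)cc1)c1ccc(Br)cc1` gives 10000 nM

In a functional assay on DU-145 cells (Homo sapiens) for inhibition, read by trypan blue exclusion, with a stated time of 96 h (on this read-out lower numbers stand for stronger inhibition of growth and higher numbers for weaker inhibition of growth), compound 3 stands level with compound 2, and the two share the lowest number of the three. The next compound, compound 4 `Nc1c(Br)cc(Br)cc1/C=C(\C(=O)c1ccc(Br)cc1)S(=O)(=O)c1ccc(Br)cc1`, differs from compound 3 in one place: 2-amino-3,5-dibromophenyl in place of 4-bromo-3-nitrophenyl on a double-bonded chain carbon bound to a double-bonded chain carbon. For the measured compounds named here, three measured steps bear on this place: a 2.5-fold lower number from compound 1 to compound 2 (0.40 log units; beyond the scatter), then a 2.5-fold lower number from compound 1 to compound 3 (0.40 log units; beyond the scatter), and no change at the digits printed from compound 2 to compound 3 (within the scatter). Going by the values given here, these steps are modest at most, and no measurement yet covers the entering group, so no clear direction can be argued. The expected change is small, and the estimated step is no change at the digits printed from compound 3 to compound 4 (within the scatter). The estimate for compound 4 is 10000 nM, with an expected range from 4000 nM to 25000 nM.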

Compound 4, concentration for 50% growth inhibition: 25000 nM
The estimate for compound 4 lay 2.5-fold (0.40 log units) below the measured number, within the range that was stated.
By their numbers in this assay, from the lowest: compounds 2 and 3 (each within the scatter of the next); then compounds 1 and 4 (each within the scatter of the next).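

At this place, a new aromatic group can also weaken growth inhibition: 2-amino-3,5-dibromophenyl gives a 2.5-fold higher number from compound 3 to compound 4 (0.40 log units; beyond the scatter) and a 2.5-fold higher number from compound 2 to compound 4 (0.40 log units; beyond the scatter) in this comparison. Set against 4-methoxyphenyl, it gives no change at the digits printed from compound 1 to compound 4 (within the scatter) and so shows that not every replacement of that group lowers the number. Nothing available explains these differences.

The compounds shown cannot separate the part played by the amine from that of the two bromines. On these data alone, how a carboxylic acid or a single fluorine on this ring would behave also stays open.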